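A fluorine on the anilino ring of compound 2

The compounds below may be only part of what the source reports. "The series", "measured", "known", "first", "only" and "open" are said of these compounds alone.

Of the compounds shown here, three sharing one core have been tested so far. In a functional assay on MGC-803 cells (Homo sapiens) for inhibition, read by MTT assay, with a stated time of 72 h (a higher number here means a weaker inhibitor, a lower number a stronger inhibitor), compound 1 `O=C(CSc1nc(Nc2ccccc2)c2ccccc2n1)Nc1ccccc1Br` gives 18600 nM, and compound 2 `C=CC(=O)Nc1cccc(NC(=O)CSc2nc(Nc3ccccc3)c3ccccc3n2)c1` gives 7310 nM. Compound 3 `CCc1ccc(NC(=O)CSc2nc(Nc3ccccc3)c3ccccc3n2)cc1` reaches only the limit of > 50000 nM in this assay, which is not a number but the edge of what the assay reports. Compound 2 therefore stands lowest of the two numbers shown, with compound 1 as the nearest: a 2.5-fold lower number from compound 1 to compound 2 (0.41 log units; beyond the scatter). The other steps, an at least 2.6-fold higher number from compound 1 to compound 3 (0.42 log units; beyond the scatter) and an at least 6.8-fold higher number from compound 2 to compound 3 (0.83 log units; beyond the scatter), rest on a limit of > 50000 nM in this assay, at which 1 of the 3 values shown sits, and all three steps change the aryl group on the amide nitrogen.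

Compound 4 `C=CC(=O)Nc1cccc(NC(=O)CSc2nc(Nc3cccc(F)c3)c3ccccc3n2)c1` differs from compound 2 elsewhere: fluoro in place of hydrogen on an aromatic carbon. This is fluoro in place of hydrogen on an aromatic carbon, a phenyl becoming a 3-fluorophenyl, anilino becoming (3-fluorophenyl)amino. Among the compounds with values here, no measured step touches this ring, so none bears directly on the change; the measured steps only show how much the numbers move when the amide-side aryl is altered. Small additions of this kind usually leave a number within the scatter, so the expected step from compound 2 to compound 4 in this assay is a 1.0-fold lower number from compound 2 to compound 4 (0.02 log units; within the scatter), with no clear direction. Compound 4 is estimated at 7000 nM, within a range of 3000 nM to 18000 nM.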

Compound 4, half-maximal inhibitory concentration: 6250 nM
The estimate for compound 4 lay 1.1-fold (0.05 log units) above the measured number; measured number inside the range.
By their numbers in this assay, from the lowest: compounds 4 and 2 (each within the scatter of the next); then compound 1. At a limit, above all of these: compound 3.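

In this assay the anilino ring shows its first measured change, and the fluoro in place of hydrogen gives a 1.2-fold lower number from compound 2 to compound 4 (0.07 log units; within the scatter), so phenyl and 3-fluorophenyl cannot be told apart at this place in this read-out. The earlier steps shown here all changed the aryl group on the amide nitrogen and were printed as beyond the scatter, whereas this step shows that a fluoro meta to a large group on the other aromatic ring can be present without a measurable shift. Nothing in the data shown explains why this step is so small.

From the compounds shown here alone, one fluorine atom at one place says little about the ring as a whole, so it remains open whether a methoxy, a trifluoromethyl or a dimethylamino group at the same place would also leave the number within the scatter. Going by these compounds, it also remains open whether the same fluoro would read alike with the 2-bromophenyl group of compound 1 on the amide nitrogen, and whether a propanoyl group could stand in for the vinylcarbonyl group of compound 4.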